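Cyano in place of methoxy: compound 2 to compound 4

The source may hold more compounds than are shown below. What is called first, only, known or untested is meant among the compounds shown, and "the series" means these compounds.

Compound 1 `CC/C=C/C(=O)Nc1cccc(Oc2nc(Nc3cccc(OC)c3)nc3c2CSCC3)c1`: 27200 nM
Compound 2 `COc1cccc(Nc2nc3c(c(Oc4cccc(NC(=O)/C=C/C(C)C)c4)n2)CSCC3)c1`: > 50000 nM (a limit)
Compound 3 `C=C(F)C(=O)Nc1cccc(Oc2nc(Nc3cccc(OC)c3)nc3c2CSCC3)c1`: 44800 nM

All three compounds were tested in a functional assay on HeLa cells (Homo sapiens) for antiproliferative activity, read by MTT assay, with a stated time of 72 h (on this read-out higher numbers stand for weaker inhibition and lower numbers for stronger inhibition), and share one core. Compound 2 has no number in this test, only the limit > 50000 nM of the assay. It stands at (the limit of > 50000 nM in this assay, at which 1 of the 3 values shown sits) and so can be placed only at the top edge of the values shown.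

Compound 4 `CC(C)/C=C/C(=O)Nc1cccc(Oc2nc(Nc3cccc(C#N)c3)nc3c2CSCC3)c1` keeps the chain on the carbonyl carbon of compound 2 and has 3-cyanophenyl in place of 3-methoxyphenyl (cyano in place of methoxy on an aromatic carbon). The group changes on an aromatic carbon, meta to a large group.

The measured steps change only the chain on the carbonyl carbon: an at least 1.8-fold higher number from compound 1 to compound 2 (0.26 log units; that floor lies within the scatter) and a 1.6-fold higher number from compound 1 to compound 3 (0.22 log units; within the scatter) and also an at least 1.1-fold lower number from compound 2 to compound 3 (0.04 log units; that floor lies within the scatter) (all within the scatter). None of them touches the methoxy group, so the data give no direct size for this change. The nearest numbers are high, with compound 1 at 27200 nM and compound 3 at 44800 nM in the same test. A reading near the top of the range therefore seems likely, and there may again be only a limit.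

The expected step is an at least 1.2-fold lower number from compound 2 to compound 4 (0.09 log units; that floor lies within the scatter) and no change beyond the scatter is expected. In this assay the expected value for compound 4 is 40000 nM within a range of 15000 nM to 70000 nM (estimated).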

Compound 4, half-maximal inhibitory concentration: 22800 nM
Compound 4: middle estimate off by 1.8-fold (0.24 log units), on the high side; low and high end bracket the measured number.
By their numbers in this assay, from the lowest: compounds 4, 1 and 3 (each within the scatter of the next). At a limit, above all of these: compound 2.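

In this assay, cyano in place of methoxy on an aromatic carbon is the first change shown away from the chain on the carbonyl carbon, and it gives an at least 2.1-fold lower number from compound 2 to compound 4 (0.34 log units; beyond the scatter), the only step in this set that lies beyond the scatter. Compound 2 stands at a limit and not at a number: the limit of > 50000 nM in this assay, at which 1 of the 4 values shown sits. The size of the step is therefore a floor, and since methoxy and cyano match in their counts of heavy atoms, hydrogen-bond donors and hydrogen-bond acceptors, it shows that this aromatic carbon can respond to a change of group even where those counts stay the same.

The compounds shown leave open whether the step carries over to the but-1-en-1-yl or 1-fluoroethenyl chains on the carbonyl carbon, as cyano appears here only with the 3-methylbut-1-en-1-yl chain. They also leave open how other groups on this aromatic carbon, such as an amine, a carboxylic acid or trifluoromethyl, would read in this assay.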